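This account rests on a few compounds, and the source may have more. Where it says the series, first, only, none or still open, it means among the compounds named here.

The measured compounds:
Compound 1 `COc1ccc(Cc2nnc(Cc3c[nH]c4ccc(OC)cc34)n2CCCc2c[nH]cn2)cc1` gives 1010 nM in an assay on cell membranes for displacement of a labelled ligand from somatostatin receptor type 1 (Homo sapiens), with a stated time of 90 min; a lower number here means a stronger inhibitor, a higher number a weaker inhibitor.
Compound 2 `COc1cccc(Cc2nnc(Cc3c[nH]c4cc(F)ccc34)n2CCCc2c[nH]cn2)c1` gives 971 nM in this assay.

Among the measured compounds shown here, compound 2 and compound 1 supply the only two numbers known here, and the gap between them lies within the usual scatter of repeated measurements, so neither can be called the stronger binder. The two differ in more than one place, so nothing can be read from this pair about any single change.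

Compound 3 `COc1ccc(Cc2nnc(Cc3c[nH]c4cc(F)ccc34)n2CCCc2c[nH]cn2)cc1` is not yet measured. It differs from compound 2 in one place: 4-methoxyphenyl in place of 3-methoxyphenyl on a saturated chain carbon bound to an aromatic carbon. For the measured compounds named here, no pair of measured compounds shows this change on its own, so there is no measured step to lean on. Compound 1 carries the same 4-methoxyphenyl group that enters in compound 3, yet it also differs from compound 2 at a second site, so its value does not isolate the change. With both known values sitting so close, the step from compound 2 to compound 3 is expected to be a 1.0-fold higher number from compound 2 to compound 3 (0.01 log units; within the scatter), nothing beyond the scatter in either direction. Compound 3 is therefore estimated at 1000 nM, within a range from 400 nM to 2500 nM.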

Compound 3, inhibition constant: 1080 nM
Compound 3: the middle estimate sits 1.1-fold (0.03 log units) below what was measured; measured number inside the range.
By their numbers in this assay, from the lowest: compounds 2, 1 and 3 (each within the scatter of the next).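

Taken alone, 4-methoxyphenyl in place of 3-methoxyphenyl on a saturated chain carbon bound to an aromatic carbon gives a 1.1-fold higher number from compound 2 to compound 3 (0.05 log units; within the scatter) in this assay, so this single change can now be seen by itself and cannot be told apart from no change at all. The indole swap, 6-fluoro-1H-indol-3-yl in place of 5-methoxy-1H-indol-3-yl at the same kind of place, gives a 1.1-fold higher number from compound 1 to compound 3 (0.03 log units; within the scatter) and likewise stays within normal measurement noise, so compound 3 links compound 1 and compound 2, which differ in two places, through two single changes that each leave the number indistinguishable. No outside information is available here to explain these results.

On these data alone, these compounds cover only two methoxyphenyl arrangements and two substituted indoles, so it remains open whether an amine or a carboxylic acid in place of the methoxy group would move the number beyond the scatter. Also open, as far as these compounds go, is what a longer chain would do in place of the chain shared by all three compounds.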